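The source may report more compounds than this note shows. Statements on the series, on what has been measured and on what is new or still open speak of the compounds shown alone.

For the measured compounds named here, compound 3 `O=C(O)c1ccccc1-c1ccc(CCc2ncc(Cc3cccc(F)c3)[nH]2)cc1` gives the lowest of the three numbers so far in an in vitro functional assay on cells for agonist activity at Bombesin receptor subtype-3 (Homo sapiens), read by luminescence and calcium flux (a lower number here means that less compound is needed, a higher number that more compound is needed for the effect), with 159 nM. Its nearest neighbour is compound 1 `O=C(O)c1ccccc1-c1ccc(CCc2ncc(Cc3ccccc3F)[nH]2)cc1`, which in this assay gives 177 nM; the gap between the two, a 1.1-fold lower number from compound 1 to compound 3 (0.05 log units; within the scatter), lies within the scatter. Furthest away is compound 2 `O=C(O)c1ccccc1-c1ccc(CCc2ncc(Cc3ccc(Cl)cc3)[nH]2)cc1`, which in this assay gives 2290 nM, a step of a 14-fold lower number from compound 2 to compound 3 (1.16 log units; beyond the scatter) and, seen from the other side, a 13-fold higher number from compound 1 to compound 2 (1.11 log units; beyond the scatter).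

Compound 4 `CC(C)(C)Cc1cnc(CCc2ccc(-c3ccccc3C(=O)O)cc2)[nH]1` differs from compound 3 by tert-butyl in place of 3-fluorophenyl on a saturated chain carbon bound to an aromatic carbon. All three measured steps concern the same place, and they show that what sits there can move the number a great deal: two exchanges of one aromatic ring for another were large, one was within the scatter. Going by the values given here, no measured step, however, replaces the aromatic ring at this position by a chain group such as tert-butyl, so the three steps set the scale of what is possible here without fixing the direction.

On that basis compound 4 is expected to give a somewhat higher number than compound 3, an estimated step of a 3.1-fold higher number from compound 3 to compound 4 (0.50 log units; beyond the scatter), with wide uncertainty. The estimate for compound 4 in this assay is 500 nM, in a range from 100 nM to 3000 nM.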

Compound 4, half-maximal effective concentration: 106 nM
For compound 4 the middle estimate is 4.7-fold (0.67 log units) above the measured one, within the range that was stated.
By their numbers in this assay, from the lowest: compounds 4, 3 and 1 (each within the scatter of the next); then compound 2.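

In this assay, an aromatic ring at this position proves dispensable among the compounds shown: with tert-butyl on the saturated chain carbon, a 1.5-fold lower number from compound 3 to compound 4 (0.18 log units; within the scatter) and a 1.7-fold lower number from compound 1 to compound 4 (0.22 log units; within the scatter) both lie within the scatter, so compound 4 stands level with the two fluorophenyl compounds. Against the 4-chlorophenyl compound the same group gives a 22-fold lower number from compound 2 to compound 4 (1.33 log units; beyond the scatter) and thus a large step, which leaves compound 2 apart from the other three. What the earlier compounds could not show is that a group with no ring and fewer heavy atoms than 3-fluorophenyl can sit here without leaving that level, so among these four compounds only 4-chlorophenyl stands out, and a ring is not what separates the three lower numbers from compound 2.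

No measurement presented offers an account of why these groups compare as they do. Going by these compounds, it remains open whether the level holds for a smaller group such as methyl, a longer chain or an amine at this place, and whether a 4-fluorophenyl or 3-chlorophenyl group would follow compound 2 or the fluorophenyl compounds.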